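Working notes on a stability series: compounds 1 to 4

The source may report more compounds than this note shows. Statements on the series, on what has been measured and on what is new or still open speak of the compounds shown alone.

Compound 1, `COc1ccc(-c2c(C)oc3c(N4CC[C@@H](NC(C)=O)C4)cc(C)nc23)cc1OC`, gives > 95% in an ADME assay on microsomes from liver (Homo sapiens) for metabolic stability, read by LC-MS, with NADPH named in the record, with a stated time of 60 min, tested at 1 uM, in the absence of a further agent; on this read-out higher numbers stand for a more stable compound and lower numbers for a less stable compound; this is a limit of the assay, not a number.
Compound 2, `CC(=O)N[C@@H]1CCN(c2cc(C)nn3c(-c4ccco4)c(C)nc23)C1`, gives > 95% in this assay; again a limit, not a number.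
Compound 3, `CCCCCC(=O)N[C@@H]1CCN(c2cc(C)nn3c(-c4ccc(OC)c(OC)c4)c(C)nc23)C1`, gives > 95% in this assay; also a limit, not a number.

Among the measured compounds shown here, no two of the measured compounds differ in a single place, so no measured step can be drawn. Compound 3 therefore stands at the limit of > 95% in this assay, at which 3 of the 3 values shown sit, and nothing in the numbers sets it apart from compound 1 or compound 2; no order among the three can be stated.

Compound 4, `COc1ccc(-c2c(C)nc3c(N4CC[C@@H](O)C4)cc(C)nn23)cc1OC`, is not yet measured in this assay. Relative to compound 3 the change is hydroxy in place of (pentylcarbonyl)amino on a saturated ring carbon. The amide and its pentyl chain are gone and a hydroxy remains at the same ring carbon.

With every measured value sitting at the limit, the step from compound 3 to compound 4 is expected to be small or none beyond the scatter, estimated as a number at least 5 percentage points lower from compound 3 to compound 4 (that floor lies within the scatter). For compound 4 the expected value in this assay is 90%, with a range from 75% to 98%.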

Compound 4, percent of the compound remaining: > 95%
Compound 4 ended at the assay's limit (the forecaster's own chance of this, stated with the estimate: 50%); middle value at least 5 percentage points away from the limit.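

In this assay compound 4 gives > 95%, a limit and not a number. Among the compounds shown here, with compound 3 also at a limit, no step between the two can be read. The compounds shown leave open how their stabilities differ, as all stand at one limit: the limit of > 95% in this assay, at which 4 of the 4 values shown sit.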